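The source may hold more compounds than are shown below. What is called first, only, known or untested is meant among the compounds shown, and "the series" means these compounds.

Of the compounds shown here, three have been measured so far.

Compound 1, `Cc1[nH]c2ccc(Br)cc2c(=O)c1Br`: in a physicochemical assay for solubility, read by HPLC, at pH 7.4 (a higher number here means a more soluble compound, a lower number a less soluble compound), compound 1 reaches only a limit, > 20000 nM.
Compound 2, `Cc1[nH]c2ccc(Cl)cc2c(=O)c1Br`: in this assay compound 2 gives 5000 nM.
Compound 3, `CCc1c(C)[nH]c2cc(OC)c(Cl)cc2c1=O`: in this assay compound 3 gives 10000 nM.

Compound 1 and compound 2 share a core and differ in one place: bromo in place of chloro on an aromatic carbon. This change gave an at least 4.0-fold higher number from compound 2 to compound 1 (0.60 log units; beyond the scatter). The upper value is a limit, (the limit of > 20000 nM in this assay, at which 1 of the 3 values shown sits), so the full size of that step is not known. Compound 3 and compound 2 have different cores; the difference between the two cores is not broken down here. The values of compound 3 and compound 2 lie within the usual scatter of each other.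

Compound 4, `CCc1c(C)[nH]c2cc(OC)c(Br)cc2c1=O`, has not yet been measured in this assay. It differs from compound 3 by the same kind of change: bromo in place of chloro on an aromatic carbon. The surroundings differ in that here the carbon is also ortho to a methoxy group (2 heavy atoms). Since the same change gave an at least 4.0-fold higher number from compound 2 to compound 1 (0.60 log units; beyond the scatter), compound 4 is expected to show a 3.0-fold higher number from compound 3 to compound 4 (0.48 log units; beyond the scatter). Compound 4 is therefore estimated at 30000 nM, most likely between 10000 nM and 80000 nM.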

Compound 4, solubility: 2000 nM
Beside the measured number, compound 4's estimate is 15-fold (1.18 log units) above it; the measured number lies below the stated range.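

In this assay, the same change, bromo in place of chloro on an aromatic carbon, gave an at least 4.0-fold higher number from compound 2 to compound 1 (0.60 log units; beyond the scatter) on one core, but a 5.0-fold lower number from compound 3 to compound 4 (0.70 log units; beyond the scatter) on the other. Both steps lie beyond the scatter and point in opposite directions, so in these two pairs the effect of the change does not carry from one core to the other, and its direction cannot be assumed on a new core; what these pairs do not show is which difference between the cores goes with the reversal, whether the methoxy group ortho to the changed carbon or something else. Compound 1 stands at a limit, so the size of the first step remains unknown: the limit of > 20000 nM in this assay, at which 1 of the 4 values shown sits.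

The compounds shown leave open whether bromo in place of chloro would give a lower or a higher number on the core of compound 4 without its methoxy group. They also leave open how the number would respond if an amine or a carboxylic acid stood in place of the halogen on either core.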